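The source may hold more compounds than are shown below. What is called first, only, known or untested is meant among the compounds shown, and "the series" means these compounds.

Compound 1, `CCCCC1=C(C(=O)OCC)C(c2cccc([N+](=O)[O-])c2)C(C(=O)OCC)=C(C)N1`: 20 nM
Compound 2, `C=CCOC(=O)C1=C(C)NC(C)=C(C(=O)OCC)C1c1cccc([N+](=O)[O-])c1`: 25 nM
Compound 3, `C#CCCOC(=O)C1=C(C)NC(C)=C(C(=O)OC)C1c1cccc([N+](=O)[O-])c1`: 31 nM

The three measured compounds share a core and differ only in the groups on a saturated chain carbon bound to an oxygen next to a carbonyl group. In a functional assay on HEK293 cells for antagonist activity at Voltage-dependent L-type calcium channel subunit alpha-1C (Oryctolagus cuniculus), read by FLIPR (a higher number here means a weaker inhibitor, a lower number a stronger inhibitor), compound 1 gives 20 nM, compound 2 gives 25 nM and compound 3 gives 31 nM. Compound 3 carries the highest of the three numbers, but its distance to compound 2 and to compound 1 each lies within the usual scatter, so the three cannot be separated on these data.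

Compound 4, `COC(=O)C1=C(C)NC(C)=C(C(=O)OCc2ccc(OC)c(OC)c2)C1c1cccc([N+](=O)[O-])c1`, has not yet been measured. It differs from compound 3 in one place: 3,4-dimethoxyphenyl in place of propargyl on a saturated chain carbon bound to an oxygen next to a carbonyl group. Going by the values given here, no step between two measured compounds is available here, so the size of this step has to be guessed from the fact that varied groups at this place have so far given numbers within the scatter of one another. The step from compound 3 to compound 4 in this assay is therefore expected to be small, if anything toward a slightly higher number, and probably not beyond the scatter: a 1.3-fold higher number from compound 3 to compound 4 (0.11 log units; within the scatter). Compound 4 is estimated at 40 nM, with a range from 12 nM to 150 nM.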

Compound 4, half-maximal inhibitory concentration: 112 nM
Beside the measured number, compound 4's estimate is 2.8-fold (0.45 log units) below it, within the range that was stated.
By their numbers in this assay, from the lowest: compounds 1, 2 and 3 (each within the scatter of the next); then compound 4.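

In this assay, putting 3,4-dimethoxybenzyl in place of but-3-yn-1-yl gives a 3.6-fold higher number from compound 3 to compound 4 (0.56 log units; beyond the scatter), so compound 4 is the weaker inhibitor of this pair. The earlier compounds shown here could not be separated, whereas this modest step shows that the group at this place can change the reading and that not every group is equivalent here. No measurement shown explains the change.

The step brings in the six-membered aromatic ring and its two methoxy groups together, so the compounds shown cannot say which of them matters; an unsubstituted benzyl group at this place would help separate the two. From the compounds shown here alone, how an amine or a carboxylic acid at the end of the chain would read in this assay also remains open.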